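The source may report more compounds than this note shows. Statements on the series, on what has been measured and on what is new or still open speak of the compounds shown alone.

Measured so far in a functional assay for agonist activity at growth hormone secretagogue receptor type 1 (Homo sapiens), read by FLIPR; a lower number here means a smaller maximal response, a higher number a larger maximal response:
compound 1, `C[C@@H]1CN(c2ccc(F)c(NS(=O)(=O)c3ccc(-c4ccccn4)s3)c2)C[C@H](C)N1`, gives 0.8
compound 2, `COc1ccc(F)c(-c2ccc(S(=O)(=O)Nc3cc(N4C[C@@H](C)N[C@@H](C)C4)ccc3OC)cc2)c1`, gives 1.2

Compound 2 stands highest of the two numbers; compound 1 sits below it by a gap beyond the usual scatter. The next compound, compound 3, `COc1ccc(N2C[C@@H](C)N[C@@H](C)C2)cc1NS(=O)(=O)c1ccc(Oc2ccccc2)cc1`, differs from compound 2 in one place: phenoxy in place of 2-fluoro-5-methoxyphenyl on an aromatic carbon. Going by the values given here, no measured pair shows this exchange, so its effect is unknown. Among the compounds with values here, a modest drop in this assay is expected, probably beyond the scatter, as the only other number, for compound 1 at 0.8, is lower. The expected step is a number 0.20 lower from compound 2 to compound 3 (beyond the scatter). Compound 3 is estimated at 1, within 0.7 to 1.3.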

Compound 3, intrinsic activity: the largest response reached, as a fraction of the reference agonist's: 0.9
Estimate against measurement, compound 3: 0.10 above; measured number inside the range.
By their numbers in this assay, from the lowest: compounds 1 and 3 (each within the scatter of the next); then compound 2.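

In this assay phenoxy in place of 2-fluoro-5-methoxyphenyl on this aromatic carbon brings a number 0.30 lower from compound 2 to compound 3 (beyond the scatter) and so shows that the group held here shapes the maximal response. Even so, compound 3 gives 0.9 and so keeps a clear response with phenoxy at this position. No measurement shown here explains this step. Which part of the exchange matters stays open: the fluorine, the methoxy or the oxygen of phenoxy. Going by these compounds, how an amine or a carboxylic acid at this position would behave also stays open.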